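A few compounds are considered here, and "the series" means these few. Any claim that something is new, unique, unknown or untested is made for them only; others in the source may bear on it.

Measured compounds:
Compound 1 `Cc1cc(C(=O)Nc2ccccc2)nn1Cc1cc(Cl)ccc1OCc1ccccc1`: in a physicochemical assay for lipophilicity, at pH 7.4 (on this read-out lower numbers stand for lower lipophilicity and higher numbers for higher lipophilicity), compound 1 gives > 3.7, which is a limit of the assay and not a number.
Compound 2 `Cc1cc(NC(=O)C2CCOC2)nn1Cc1cc(Cl)ccc1OCc1ccccc1`: in this assay compound 2 gives > 3.7, again a limit and not a number.

Compound 1 therefore stands only at the ceiling of this assay, with no readable number of its own. Going by the values given here, the one measured step, a step that the two limits leave unreadable from compound 1 to compound 2, is likewise unreadable, since both ends sit at the ceiling (the limit of > 3.7 in this assay, at which 2 of the 2 values shown sit). The unmeasured compound 3 `Cc1cc(NC(=O)OCc2ccccc2)nn1Cc1cc(Cl)ccc1OCc1ccccc1` differs from compound 1 in one place: (benzyloxycarbonyl)amino in place of phenylcarbamoyl on an aromatic carbon. No measured step matches this change, so nothing shown gives its size or direction; the only guidance is that both measured compounds, whatever their substituent on that aromatic carbon, reach the ceiling of this assay. Compound 3 is therefore expected to sit at or beyond that ceiling as well, with a change of a step that the limit leaves unreadable from compound 1 to compound 3 estimated, and an estimated value of 4.3, lying between 3.6 and 5.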

Compound 3, distribution coefficient: 3.1
The estimate for compound 3 lay 1.20 log units above the measured number, and the stated range ends above it.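

Going by these compounds alone, compound 3 gives the first readable number for this series in this assay, so the substituent on this aromatic carbon of the shared core is able to bring a compound down from the ceiling: the limit of > 3.7 in this assay, at which 2 of the 3 values shown sit. Putting (benzyloxycarbonyl)amino in place of phenylcarbamoyl on the aromatic carbon gives a number at least 0.60 log units lower from compound 1 to compound 3 (beyond the scatter), although the entering group keeps a six-membered aromatic ring of carbon only, so that ring alone does not hold a compound at the ceiling. Putting benzyloxy in place of oxolan-3-yl on the carbonyl carbon gives a number at least 0.60 log units lower from compound 2 to compound 3 (beyond the scatter), which shows that the group on that carbonyl carbon also matters in this series.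

On these data alone, the step between compound 1 and compound 2 still cannot be read, and both steps to compound 3 give only a smallest size, so their full size remains open. Also open, as far as these compounds go, is how an amine, a carboxylic acid or a longer alkyl chain on this aromatic carbon would read in this assay, and whether any of them would fall further than compound 3 does.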